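This account rests on a few compounds, and the source may have more. Where it says the series, first, only, none or still open, it means among the compounds named here.

Measured in an in vitro ADME assay on microsomes from liver (Homo sapiens) for pharmacokinetics, read by LC-MS, with a stated time of 10 min, tested at 1 uM; a higher number here means faster removal of the compound, a lower number slower removal:
- compound 1 `CN1C[C@H](C(=O)Nc2ccc(C#N)cc2)[C@@H](c2ccc(/C=C/C(=O)Nc3ccccc3N)cc2)C1` gives 1 mL/min/kg
- compound 2 `CN1C[C@H](C(=O)Nc2ccc(C(F)(F)F)cc2)[C@@H](c2ccc(/C=C/C(=O)Nc3ccccc3N)cc2)C1` gives 6 mL/min/kg
- compound 3 `CN1C[C@H](C(=O)Nc2ccc(F)c(Br)c2)[C@@H](c2ccc(/C=C/C(=O)Nc3ccccc3N)cc2)C1` gives 15 mL/min/kg

Compound 3 has the highest number of the three, and it stands clear of both others. The data show a 2.5-fold higher number from compound 2 to compound 3 (0.40 log units; beyond the scatter) as the smaller gap and a 15-fold higher number from compound 1 to compound 3 (1.18 log units; beyond the scatter) as the larger one.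

Compound 4 `CN1C[C@H](C(=O)Nc2ccc(F)cc2F)[C@@H](c2ccc(/C=C/C(=O)Nc3ccccc3N)cc2)C1` differs from compound 3 in a single group: 2,4-difluorophenyl in place of 3-bromo-4-fluorophenyl on an amide-type nitrogen with the shared core unchanged.

Going by the values given here, all the measured steps alter the aromatic group at this same place, and all are beyond the scatter. Alongside the two gaps above, there is a 6.0-fold higher number from compound 1 to compound 2 (0.78 log units; beyond the scatter) as a further modest step. Among the compounds with values here, no measured compound carries 2,4-difluorophenyl, so these steps suggest a size more than a firm direction. Since compound 3 sits at the high end with 15 mL/min/kg as its number, a new group here seems more likely to land lower than higher. A modest fall is therefore expected, comparable in size to the gap between compound 2 and compound 3.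

The estimate is a 2.5-fold lower number from compound 3 to compound 4 (0.40 log units; beyond the scatter) as the expected step. The expected value for compound 4 is 6 mL/min/kg within an estimated range of 2 mL/min/kg to 15 mL/min/kg in this measurement.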

Compound 4, clearance: 12 mL/min/kg
For compound 4 the middle estimate is 2.0-fold (0.30 log units) below the measured one; the measured number falls inside the stated range.
By their numbers in this assay, from the lowest: compound 1; then compounds 2, 4 and 3 (each within the scatter of the next, the first and the last beyond it).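

In this assay, 2,4-difluorophenyl in place of 3-bromo-4-fluorophenyl on the amide-type nitrogen gives a 1.3-fold lower number from compound 3 to compound 4 (0.10 log units; within the scatter) and so leaves compound 3 and compound 4 indistinguishable, even though a second fluorine replaces the bromine and the group keeps the same count of heavy atoms. Compound 4 also stands within the scatter of the 4-(trifluoromethyl)phenyl compound, with a 2.0-fold higher number from compound 2 to compound 4 (0.30 log units; within the scatter) as the step, so it bridges two compounds that are themselves separated by a 2.5-fold higher number from compound 2 to compound 3 (0.40 log units; beyond the scatter) and shows that the clearance at this position can take intermediate values, while a 12-fold higher number from compound 1 to compound 4 (1.08 log units; beyond the scatter) leaves the 4-cyanophenyl compound alone at the low end. Nothing available here explains why these groups give the numbers they do.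

As far as these compounds go, how the clearance would respond to a plain phenyl with no halogen, or to an aromatic ring carrying an amine or a carboxylic acid, stays open at this amide-type nitrogen. From the compounds shown here alone, all four compounds also share the same core, so it remains unknown whether these steps would keep their size if another part of the molecule were changed.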